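The source may hold more compounds than are shown below. What is called first, only, known or untested is meant among the compounds shown, and "the series" means these compounds.

Of the compounds shown here, three sharing one core have been measured in a functional assay on KB cells (Homo sapiens) for cytotoxicity; a higher number here means a weaker inhibitor, a lower number a stronger inhibitor. Compound 1 `COc1ccc(S(=O)(=O)N2CCc3cccc(NC(=O)c4ccc(C#N)cc4)c32)cc1` gives 105 nM. Compound 2 `COc1ccc(S(=O)(=O)N2CCc3cccc(NC(=O)c4ccncc4)c32)cc1` gives 9.6 nM, and compound 3 `COc1ccc(S(=O)(=O)N2CCc3cccc(NC(=O)c4ccco4)c32)cc1` gives 9.6 nM. Compound 3 therefore sits level with compound 2, the two sharing the lowest number of the three, while compound 1 lies well apart: an 11-fold lower number from compound 1 to compound 3 (1.04 log units; beyond the scatter). The only variable among these three is the group attached to the carbonyl carbon of the amide, and two of the three swaps were large (an 11-fold lower number from compound 1 to compound 2 (1.04 log units; beyond the scatter); an 11-fold lower number from compound 1 to compound 3 (1.04 log units; beyond the scatter)), whereas no change at the digits printed from compound 2 to compound 3 (within the scatter).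

Compound 4 `COc1ccc(S(=O)(=O)N2CCc3cccc(NC(=O)C(C)(C)C)c32)cc1` changes the same spot once more: tert-butyl in place of furan-2-yl on a carbonyl carbon. Among the measured compounds shown here, every earlier swap exchanged one ring for another ring; none placed a group without a ring on the carbonyl carbon, so the measured steps give no direct precedent for this move. They do show that the group on the carbonyl carbon can shift this assay by a large step or leave it unchanged, which leaves the direction of the new step open. Compound 4 is expected to land a 3.1-fold higher number from compound 3 to compound 4 (0.49 log units; beyond the scatter) in this assay, with wide uncertainty on either side. The estimate for compound 4 is 30 nM, between 8 nM and 150 nM.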

Compound 4, half-maximal inhibitory concentration: 359 nM
Beside the measured number, compound 4's estimate is 12-fold (1.08 log units) below it; the whole stated range lies below it.
By their numbers in this assay, from the lowest: compounds 2 and 3 (each within the scatter of the next); then compound 1; then compound 4.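

In this assay, tert-butyl is the only group shown on the carbonyl carbon that has no ring, and it gives a 37-fold higher number from compound 3 to compound 4 (1.57 log units; beyond the scatter) and a 37-fold higher number from compound 2 to compound 4 (1.57 log units; beyond the scatter), even though the swap from furan-2-yl only goes from 5 heavy atoms to 4. It also gives a 3.4-fold higher number from compound 1 to compound 4 (0.53 log units; beyond the scatter), so all three ring-bearing groups, including 4-cyanophenyl, give lower numbers than tert-butyl, and none of the four compounds goes against this. No measured evidence here accounts for the size of these steps.

Tert-butyl differs from furan-2-yl in two ways at once, losing both the ring and the hydrogen-bond acceptor, so the compounds shown leave open which of these differences goes with the higher number. A cyclohexyl group, which is a ring of carbon only, and a methoxymethyl group, a ringless chain that contains oxygen, would pull these two differences apart on the same carbonyl carbon.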